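Swapping Phenylsulfanyl for Methyl at the Shared Core

The source may report more compounds than this note shows. Statements on the series, on what has been measured and on what is new or still open speak of the compounds shown alone.

Measured so far in a functional assay on HEK293 cells for antagonist activity at proteinase-activated receptor 4 (Homo sapiens), read by FLIPR and calcium flux, with a stated time of 30 min; a lower number here means a stronger inhibitor, a higher number a weaker inhibitor:
- compound 1, `c1ccc2oc(-c3cn4nc(C5CC5)sc4n3)cc2c1`: 530 nM
- compound 2, `CS(=O)(=O)c1nn2cc(-c3cc4ccccc4o3)nc2s1`: 820 nM
- compound 3, `c1ccc(Sc2nn3cc(-c4cc5ccccc5o4)nc3s2)cc1`: 1900 nM

Compound 3 gives the highest number of the three in this assay, so it is the weakest inhibitor here; its nearest neighbour is compound 2, and compound 1 sits furthest below it, both gaps lying beyond the usual scatter.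

Compound 4, `Cc1nn2cc(-c3cc4ccccc4o3)nc2s1`, keeps the shared core of compound 3 and changes one thing: methyl in place of phenylsulfanyl on an aromatic carbon. The change sits on an aromatic carbon of a five-membered aromatic ring with two nitrogens and one sulfur, part of a fused system of two rings.

Among the compounds with values here, two measured steps bear on this. Going from a small cyclopropyl to phenylsulfanyl gave a 3.6-fold higher number from compound 1 to compound 3 (0.55 log units; beyond the scatter), and going from methylsulfonyl to phenylsulfanyl gave a 2.3-fold higher number from compound 2 to compound 3 (0.36 log units; beyond the scatter). In both cases the larger phenylsulfanyl group went with a higher number. Methyl is the smallest group of the set, so the reverse move is expected to bring the number back down, likely to the region of compound 1 and compound 2, a step of about a 2.9-fold lower number from compound 3 to compound 4 (0.47 log units; beyond the scatter).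

Compound 4 is therefore estimated at 650 nM in this assay, with a plausible range from 250 nM to 1700 nM.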

Compound 4, half-maximal inhibitory concentration: 37 nM
Beside the measured number, compound 4's estimate is 18-fold (1.24 log units) above it; measured number outside the range, below it.
By their numbers in this assay, from the lowest: compound 4; then compounds 1 and 2 (each within the scatter of the next); then compound 3.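

In this assay, the earlier swaps at this carbon moved the number only modestly or not beyond the scatter, whereas methyl opens a far wider gap. Methyl in place of phenylsulfanyl gives a 51-fold lower number from compound 3 to compound 4 (1.71 log units; beyond the scatter) and methyl in place of methylsulfonyl gives a 22-fold lower number from compound 2 to compound 4 (1.35 log units; beyond the scatter) while methyl in place of cyclopropyl still gives a 14-fold lower number from compound 1 to compound 4 (1.16 log units; beyond the scatter) so the gain is large against all three groups, including cyclopropyl, the other group made only of carbon. This position, next to the ring nitrogen and next to the ring sulfur, is therefore far more sensitive to the group it carries than the first three compounds suggested, and methyl gives a stronger inhibitor here than any other group shown.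

Whether this gain is particular to methyl or extends to ethyl, a methoxy group, an amine or a single chlorine atom stays open among these compounds. No measurement shown here speaks to why methyl stands so far apart.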